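Pyrimidinyl for Pyridylmethyl on the Shared Core

A few compounds are considered here, and "the series" means these few. Any claim that something is new, unique, unknown or untested is made for them only; others in the source may bear on it.

Three compounds share one core and differ only in the amine attached to the thiocarbonyl carbon. In a functional assay on HeLa cells (Homo sapiens) for antiproliferative activity, read by CCK-8 assay, with a stated time of 72 h, tested at 2 uM (a lower number here means a weaker effect, a higher number a stronger effect of the compound at the concentration tested), compound 1 `Nc1ccccc1NC(=O)c1ccc(CSC(=S)N2CCN(Cc3ccccn3)CC2)cc1` gives 14.2%, the lowest of the three numbers; compound 2 `Nc1ccccc1NC(=O)c1ccc(CSC(=S)N2CCc3cc(Cl)ccc32)cc1` gives 40.1% and compound 3 `CCN(Cc1ccncc1)C(=S)SCc1ccc(C(=O)Nc2ccccc2N)cc1` gives 63.5%. Within the data shown here, the only measured step, a number 23.4 percentage points higher from compound 2 to compound 3 (beyond the scatter), exchanges the whole amine and does not touch the change leading to compound 4 `Nc1ccccc1NC(=O)c1ccc(CSC(=S)N2CCN(c3ncccn3)CC2)cc1`, which is pyrimidin-2-yl in place of (pyridin-2-yl)methyl on an amine nitrogen in a ring. Among the measured compounds shown here, no measured pair shows what this exchange does, so the step is expected to stay within the scatter, with wide uncertainty. Compound 4 is therefore estimated at 20%, with a range from 5% to 45%, corresponding to an expected step of a number 5.8 percentage points higher from compound 1 to compound 4 (within the scatter).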

Compound 4, a percentage reported as inhibition, at one concentration (the size of the read-out at that concentration, not a potency): 52.2%
Beside the measured number, compound 4's estimate is 32.2 percentage points below it; the whole stated range lies below it.
By their numbers in this assay, from the lowest: compound 1; then compound 2; then compound 4; then compound 3.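

In this assay, pyrimidin-2-yl in place of (pyridin-2-yl)methyl on an amine nitrogen in a ring gives a number 38 percentage points higher from compound 1 to compound 4 (beyond the scatter), a large step. The earlier step exchanged the whole amine, whereas this one keeps the ring and exchanges only the group on its nitrogen, showing that this position alone can carry a large change in the read-out. No measured evidence here bears on the reason for this step. On these data alone, what a pyridin-2-yl or a (pyrimidin-2-yl)methyl group would give on this nitrogen stays open, and with it whether the step follows the aromatic ring or the linking carbon.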